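This account rests on a few compounds, and the source may have more. Where it says the series, first, only, none or still open, it means among the compounds named here.

In an assay on HEK293 cells for displacement of a labelled ligand from prostaglandin D2 receptor 2 (Homo sapiens) (on this read-out lower numbers stand for stronger inhibition and higher numbers for weaker inhibition), three closely related compounds have been measured, all sharing a core that carries a carboxymethyl group and a sulfur-linked side chain. Compound 1 `O=C(O)Cn1c(SCCCOc2ccccc2)nc2ccccc21` gives 786 nM. Compound 2 `O=C(O)Cn1c(SCCc2ccccc2)nc2ccccc21` gives 881 nM. Compound 3 `O=C(O)Cn1c(SCCNc2ccccc2)nc2ccccc21` gives 7690 nM, which is the highest number of the three, and both steps leading to it are beyond the scatter: a 9.8-fold higher number from compound 1 to compound 3 (0.99 log units; beyond the scatter) and an 8.7-fold higher number from compound 2 to compound 3 (0.94 log units; beyond the scatter). The remaining step, a 1.1-fold higher number from compound 1 to compound 2 (0.05 log units; within the scatter), shows that phenyl and phenoxymethyl at this position give indistinguishable results.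

Compound 4 `CCCCCCSc1nc2ccccc2n1CC(=O)O` has not yet been measured in this assay. It differs from compound 3 in a single place: butyl in place of anilino on a saturated chain carbon, two bonds along the chain from a sulfur. The two measured steps that bear on this change both start from groups that contain a six-membered aromatic ring and end at anilino, and both show a modest loss. Among the compounds with values here, the new group contains no ring at all, so no measured step matches it closely; what the measured steps do show is that anilino is the weakest of the three side chains tried. On that basis compound 4 is expected to land somewhere between the anilino and the phenyl-bearing compounds, with an expected change of a 3.1-fold lower number from compound 3 to compound 4 (0.49 log units; beyond the scatter). The estimate for compound 4 is therefore 2500 nM, with a range from 700 nM to 9000 nM.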

Compound 4, half-maximal inhibitory concentration: 1360 nM
Compound 4: the middle estimate sits 1.8-fold (0.26 log units) above what was measured; low and high end bracket the measured number.
By their numbers in this assay, from the lowest: compounds 1, 2 and 4 (each within the scatter of the next); then compound 3.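

In this assay, butyl in place of anilino on a saturated chain carbon, two bonds along the chain from a sulfur, gives a 5.7-fold lower number from compound 3 to compound 4 (0.75 log units; beyond the scatter), so a side chain with no ring at all brings the number back out of the range of the anilino compound. Butyl also cannot be told apart from the two side chains that end in a ring, with a 1.5-fold higher number from compound 2 to compound 4 (0.19 log units; within the scatter) and a 1.7-fold higher number from compound 1 to compound 4 (0.24 log units; within the scatter) both within the scatter, so among these four compounds an aromatic ring at the end of the chain is not needed for a number of this size, and compound 3 is the only one that stands apart. No measurement shown here explains why anilino stands apart from the other side chains.

Still open, on these data alone, is whether the loss in compound 3 is tied to the nitrogen and its hydrogen, which phenoxy or N-methylanilino at the same place would help to separate. Also open, as far as these compounds go, is how the number responds to chain length, which a shorter ethyl group or a longer octyl group would begin to show.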